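This account rests on a few compounds, and the source may have more. Where it says the series, first, only, none or still open, it means among the compounds named here.

Compound 2, with the structure `COC(=O)c1ccc2c(ccn2-c2cccc(NC(=O)Nc3cccc(C(F)(F)F)c3)c2)n1`, belongs to a small set of amides and ureas built on one shared core. In an ADME assay on HS27 cells (Homo sapiens) for cytotoxicity, read by MTT assay (on this read-out higher numbers stand for weaker inhibition and lower numbers for stronger inhibition), compound 2 gives > 10000 nM, which is a limit of the assay rather than a measured number. Going by the values given here, its amide counterpart, compound 1 with the structure `COC(=O)c1ccc2c(ccn2-c2cccc(NC(=O)c3cccc(C(F)(F)F)c3)c2)n1`, is the only other compound measured here. In this assay compound 1 gives > 10000 nM, again a limit and not a number. Among the compounds with values here, the step that the two limits leave unreadable from compound 1 to compound 2 is therefore not readable, and the one piece of evidence available is the limit of > 10000 nM in this assay, at which 2 of the 2 values shown sit.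

Compound 3, with the structure `COC(=O)c1ccc2c(ccn2-c2cccc(NC(=O)c3ccc(Cl)c(C(F)(F)F)c3)c2)n1`, has not yet been measured. It differs from compound 2 by 4-chloro-3-(trifluoromethyl)phenyl in place of (3-(trifluoromethyl)phenyl)amino on a carbonyl carbon. Within the data shown here, no measured step bears on this change, since the only step recorded ends at both limits. Because both values sit at the limit of > 10000 nM in this assay, at which 2 of the 2 values shown sit, the step from compound 2 to compound 3 is expected to be a step that the limit leaves unreadable from compound 2 to compound 3, most likely leaving the result at the assay limit. Compound 3 is therefore estimated at 20000 nM, with a range from 8000 nM to 60000 nM.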

Compound 3, half-maximal inhibitory concentration: > 10000 nM
Compound 3 gave a limit, no number (the forecaster's own chance of this, stated with the estimate: 80%); the middle value lies beyond the limit too.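

In this assay compound 3 gives > 10000 nM, which is a limit of the assay and not a number. Compound 1 and compound 2 also stand at limits, so no step among these three compounds can be read. The compounds shown leave open what actual value each has, and whether any change on the shared core would give a measurable number.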